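The compounds below may be only part of what the source reports. "The series", "measured", "known", "first", "only" and "open" are said of these compounds alone.

Compound 1 `Nc1cc(C(F)(F)F)cc2c(=O)cc(N3CCN(CC4CCCCC4)CC3)sc12` gives 69.4% in an ADME assay on cells (Hepatocyte, Mus musculus) for metabolic stability, with a stated time of 30 min (on this read-out lower numbers stand for a less stable compound and higher numbers for a more stable compound), which places it lowest of the two numbers at hand. Compound 2 `CC(=O)NC1CCC(CN2CCN(c3cc(=O)c4cc(C(F)(F)F)cc([N+](=O)[O-])c4s3)CC2)CC1` gives 94.9% in this assay, a number that lies beyond the usual scatter above compound 1; as the two structures differ in more than one place, the gap shows only what the two values show. Compound 3 `O=c1cc(N2CCN(CC3CCCCC3)CC2)sc2c([N+](=O)[O-])cc(C(F)(F)F)cc12` has not been measured in this assay. It differs from compound 1 by nitro in place of amino on an aromatic carbon. Going by the values given here, no step between measured compounds that differ in one place is available to guide the expectation. A step upward of moderate size, a number 12.6 percentage points higher from compound 1 to compound 3 (beyond the scatter), is expected, because compound 2, which also carries the nitro group, gives 94.9%. The estimate for compound 3 in this assay is 82%, within a range from 62% to 98%.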

Compound 3, percent of the compound remaining: 80.6%
Estimate against measurement, compound 3: 1.4 percentage points above; low and high end bracket the measured number.
By their numbers in this assay, from the lowest: compound 1; then compound 3; then compound 2.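

With nitro in place of amino on an aromatic carbon, this assay shows a number 11.2 percentage points higher from compound 1 to compound 3 (beyond the scatter), so this position, ortho to a fused ring and meta to a trifluoromethyl group, affects the read-out when nothing else in the structure changes. With nitro held in place, hydrogen in place of acetamido on a saturated ring carbon gives a number 14.3 percentage points lower from compound 2 to compound 3 (beyond the scatter), so a change in this second place also moves the number beyond the scatter. No measurement at hand gives a reason for either step.

Going by these compounds, whether another group on the aromatic carbon, such as a nitrile or a methoxy group, would give a similar number remains open. On these data alone, it is also open whether acetamido on the saturated ring carbon would give a similar step with amino on the aromatic carbon.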